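Shortening the dienyl side chain of compound 2

A few compounds are considered here, and "the series" means these few. Any claim that something is new, unique, unknown or untested is made for them only; others in the source may bear on it.

Compound 1 `C/C=C(C)\C=C\[C@](C)(O)C/C=C/[C@H]1[C@H](O)CC(=O)[C@@H]1CC/C=C\CCC(=O)OC`: 1.23 mg/kg
Compound 2 `C/C=C(C)/C=C/[C@](C)(O)C/C=C/[C@H]1[C@H](O)CC(=O)[C@@H]1CC/C=C\CCC(=O)OC`: 0.185 mg/kg

Within the data shown here, in a functional assay on the whole organism with Rattus norvegicus as the target (on this read-out lower numbers stand for an effect already at smaller amounts and higher numbers for an effect only at larger amounts of compound), compound 2 gives 0.185 mg/kg, the lower of the two numbers so far, so it acts at the smaller dose. Compound 3 `C=C/C=C(\C)[C@](C)(O)C/C=C/[C@H]1[C@H](O)CC(=O)[C@@H]1CC/C=C\CCC(=O)OC` has not yet been measured. It carries 1-methylbuta-1,3-dien-1-yl in place of 3-methylpenta-1,3-dien-1-yl, on a saturated chain carbon bound to an oxygen on a saturated carbon and two saturated chain carbons (1-methylbuta-1,3-dien-1-yl in place of 3-methylpenta-1,3-dien-1-yl on a saturated chain carbon bound to an oxygen on a saturated carbon and two saturated chain carbons).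

Among the measured compounds shown here, only one measured step bears on this group: a 6.6-fold lower number from compound 1 to compound 2 (0.82 log units; beyond the scatter), which lies beyond the scatter. It is due to the fact that compounds 1 and 2 differ only in the configuration as drawn, with one double bond of this same group drawn Z in compound 1 and E in compound 2. For the measured compounds named here, no measured compound yet has the shorter group, so this single step is only a rough guide. A change in this group has mattered once, so a move to a higher number in this assay, of similar or smaller size, seems likely. The expected step is a 3.2-fold higher number from compound 2 to compound 3 (0.51 log units; beyond the scatter). For compound 3 the estimated value is 0.6 mg/kg, with an expected range from 0.15 mg/kg to 2.5 mg/kg.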

Compound 3, dose for half-maximal effect: > 3.16 mg/kg
Compound 3 gave a limit, no number; the forecaster's own chance of this, stated with the estimate: 5%; middle value at least 5.2-fold (0.72 log units) away from the limit.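

Compound 3 gives no number in this assay, only a limit of the assay: the limit of > 3.16 mg/kg in this assay, at which 1 of the 3 values shown sits.

Until now, the only change seen in this group was one of geometry, which already moved the dose, as a 6.6-fold lower number from compound 1 to compound 2 (0.82 log units; beyond the scatter) shows: the fact that compounds 1 and 2 differ only in the configuration as drawn

Compound 3 shows that the makeup of the group matters too, since 1-methylbuta-1,3-dien-1-yl in place of 3-methylpenta-1,3-dien-1-yl gives an at least 17-fold higher number from compound 2 to compound 3 (1.23 log units; beyond the scatter), and the same exchange gives an at least 2.5-fold higher number from compound 1 to compound 3 (0.40 log units; beyond the scatter), so the exchange moves the number beyond the scatter from both double-bond forms of the larger group.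

As far as these compounds go, how far the dose of compound 3 lies past its limit stays open, and with it the full size of both new steps. The exchange also removes a carbon and changes where the methyl group sits, so the compounds shown cannot separate these two changes, and they do not tell whether a longer chain such as 3-methylhexa-1,3-dien-1-yl or a phenyl ring in this place would keep a dose as low as that of compound 2.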